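This account rests on a few compounds, and the source may have more. Where it says the series, first, only, none or still open, it means among the compounds named here.

Compound 1, `O=C(Nc1ccc(Oc2ccnc3[nH]ccc23)cc1)c1cn(-c2ccccc2)c2ccccc2c1=O`, is the starting point. In a functional assay on A549 cells (Homo sapiens) for inhibition, read by MTT assay, with a stated time of 72 h (a lower number here means a stronger inhibitor, a higher number a weaker inhibitor), compound 1 gives 1030 nM. Compound 2, `O=C(Nc1ccc(Oc2ccnc3[nH]ccc23)cc1)c1cn(-c2ccc(F)cc2)c2ccccc2c1=O`, carries a single alteration, (fluoro in place of hydrogen on an aromatic carbon), and in this assay compound 2 gives 390 nM. That single alteration made a 2.6-fold lower number from compound 1 to compound 2 (0.42 log units; beyond the scatter).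

Compound 3, `Cn1ccc2c(Oc3ccc(NC(=O)c4cn(-c5ccccc5)c5ccccc5c4=O)cc3F)ccnc21`, is built on a different core; the difference between the two cores is not broken down here. In this assay compound 3 gives 1720 nM, a value within the usual scatter of that of compound 1, so the two cannot be ranked against each other, while the gap to compound 2 is beyond the scatter.

Compound 4, `Cn1ccc2c(Oc3ccc(NC(=O)c4cn(-c5ccc(F)cc5)c5ccccc5c4=O)cc3F)ccnc21`, has not yet been measured. It relates to compound 3 exactly as compound 2 relates to compound 1, through (fluoro in place of hydrogen on an aromatic carbon), at the same kind of place on the same kind of ring. Because a 2.6-fold lower number from compound 1 to compound 2 (0.42 log units; beyond the scatter), the same change is expected to give a 2.5-fold lower number from compound 3 to compound 4 (0.39 log units; beyond the scatter). On that basis compound 4 is estimated at 700 nM in this assay, most likely between 300 nM and 1600 nM.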

Compound 4, half-maximal inhibitory concentration: 1460 nM
Beside the measured number, compound 4's estimate is 2.1-fold (0.32 log units) below it; the measured number falls inside the stated range.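

On the second core, the swap of phenyl to 4-fluorophenyl gives in this assay a 1.2-fold lower number from compound 3 to compound 4 (0.07 log units; within the scatter), so on this core the change cannot be told apart from no change at all. Set beside the step on the first core, which lay beyond the scatter, this might look like a failure to carry over, yet the two steps themselves cannot be told apart: the same change on two cores in this assay, a 2.6-fold lower number (0.42 log units; beyond the scatter) from compound 1 to compound 2 and a 1.2-fold lower number (0.07 log units; within the scatter) from compound 3 to compound 4, 2.2-fold (0.35 log units) apart, within the scatter of two such steps. The result therefore shows neither that the fluoro effect transfers between the two cores nor that it is lost, and a single pair on each core cannot settle the question.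

The compounds shown leave open whether another group at the same place on this ring, such as chloro, methoxy or an amine, would give a step beyond the scatter on both cores. They also leave open which of the differences between the two cores, if any, bears on the size of the step.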